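A methyl for a fluoro on the N-aryl ring

The source may hold more compounds than are shown below. What is called first, only, known or untested is meant among the compounds shown, and "the series" means these compounds.

The series shares one core, shown in compound 1 `COc1ccccc1N1C(=O)CSC1c1cc(F)cc(C(=O)O)c1`, which in a functional assay on 143B cells (Homo sapiens) for inhibition, read by CCK-8 assay, with a stated time of 72 h, tested at 1 uM (on this read-out lower numbers stand for less inhibition and higher numbers for more inhibition at the one concentration tested (going by the name of the read-out)), gives 0%. Compound 2 `O=C(NCCCCc1ccccc1)c1cccc(C2SCC(=O)N2c2cccc(F)c2)c1`, carrying an amide to a four-carbon chain ending in phenyl, gives 63% in this assay, the highest of the three numbers shown. The ring sulfur of compound 2 is replaced by oxygen in compound 3 `O=C(NCCCCc1ccccc1)c1cccc(C2OCC(=O)N2c2cccc(F)c2)c1`, and in this assay compound 3 gives 0%. Its number lies below that of compound 2, and the gap is beyond the usual scatter. Compound 4 `Cc1cccc(N2C(=O)CSC2c2cccc(C(=O)NCCCCc3ccccc3)c2)c1` has not yet been measured. It differs from compound 2 in one place: methyl in place of fluoro on an aromatic carbon, on an aromatic carbon of a six-membered aromatic ring of carbon only, meta to a large group. Within the data shown here, no pair of measured compounds shows this change, so the data give no direct step to lean on. Both groups are single heavy atoms with no donors or acceptors, so the step from compound 2 to compound 4 is expected to be small, most likely none beyond the scatter, with a slight lean toward less inhibition: a number 8 percentage points lower from compound 2 to compound 4 (within the scatter). Compound 4 is therefore estimated at 55% in this assay, within a range from 30% to 75%.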

Compound 4, a percentage reported as inhibition, at one concentration (the size of the read-out at that concentration, not a potency): 71%
Beside the measured number, compound 4's estimate is 16 percentage points below it, within the range that was stated.
By their numbers in this assay, from the lowest: compounds 1 and 3 (each within the scatter of the next); then compounds 2 and 4 (each within the scatter of the next).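

In this assay, among these compounds, the change from 3-fluorophenyl to 3-methylphenyl gives a number 8 percentage points higher from compound 2 to compound 4 (within the scatter), the first direct reading of any change at this position. Compound 3 had shown that the number can be lost through a single change at the ring sulfur, whereas this exchange of one heavy atom for another on the aromatic ring leaves the two compounds indistinguishable at the one concentration tested. Nothing measured here bears on the reason for this result.

As far as these compounds go, whether a trifluoromethyl, an amine or a carboxylic acid at the same place would also hold the number remains open. So does whether methyl, like fluoro, would lose it with oxygen in place of the ring sulfur, and how a shorter or longer chain than the four-carbon one would read.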